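Pyrazin-2-yl for pyridin-2-yl in the tert-butyl series

This account rests on a few compounds, and the source may have more. Where it says the series, first, only, none or still open, it means among the compounds named here.

Three compounds on one shared core have numbers in a physicochemical assay for solubility, in phosphate buffer, with a stated time of 18 h; on this read-out lower numbers stand for lower solubility and higher numbers for higher solubility. Compound 1 `CC(C)(C)c1nc(-c2ccsc2)c2c(N)c(C#N)c(N)nc2n1` gives 40000 nM, compound 2 `CC(C)(C)c1nc(-c2ccccc2)c2c(N)c(C#N)c(N)nc2n1` gives 4000 nM and compound 3 `CC(C)(C)c1nc(-c2ccccn2)c2c(N)c(C#N)c(N)nc2n1` gives 87000 nM. Compound 3 therefore holds the highest number of the three, beyond the scatter from both others.

The next step leads to compound 4 `CC(C)(C)c1nc(-c2cnccn2)c2c(N)c(C#N)c(N)nc2n1`, not yet measured in this assay. The change is pyrazin-2-yl in place of pyridin-2-yl on an aromatic carbon, next to the ring nitrogen.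

Going by the values given here, three measured steps bear on it. The large one is a 22-fold higher number from compound 2 to compound 3 (1.34 log units; beyond the scatter), with pyridin-2-yl in place of phenyl. Two modest ones are a 2.2-fold higher number from compound 1 to compound 3 (0.34 log units; beyond the scatter), with pyridin-2-yl in place of thiophen-3-yl, and a 10-fold lower number from compound 1 to compound 2 (1.00 log units; beyond the scatter), with phenyl in place of thiophen-3-yl. Among the compounds with values here, none of them starts from pyridin-2-yl, and no measured compound carries pyrazin-2-yl, so these steps give only a weak guide. Both steps that introduce pyridin-2-yl went upward, which points to a small rise rather than a repeat of the large step.

The expected step is a 1.5-fold higher number from compound 3 to compound 4 (0.17 log units; within the scatter). For compound 4 the estimated value is 130000 nM, with an expected range of 50000 nM to 350000 nM.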

Compound 4, solubility: 86000 nM
Compound 4: the middle estimate sits 1.5-fold (0.18 log units) above what was measured, and the stated range covers the measured number.
By their numbers in this assay, from the lowest: compound 2; then compound 1; then compounds 4 and 3 (each within the scatter of the next).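

In this assay, going by these compounds alone, pyrazin-2-yl in place of pyridin-2-yl gives a 1.0-fold lower number from compound 3 to compound 4 (0.01 log units; within the scatter), the only step at this position that stays within the scatter, so the read-out does not separate these two groups. Against the other two groups, pyrazin-2-yl gives a 22-fold higher number from compound 2 to compound 4 (1.33 log units; beyond the scatter) and a 2.2-fold higher number from compound 1 to compound 4 (0.33 log units; beyond the scatter), which closely track the steps seen for pyridin-2-yl; in these four compounds, the six-membered aromatic ring with 2 hetero atoms adds nothing measurable beyond the ring with 1 hetero atom, while phenyl, with no ring hetero atom, stands far lower. No supporting measurement is available to explain why the two groups read alike or why both stand apart from phenyl.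

Still open, from the compounds shown here alone, is whether this level holds for other groups on the same aromatic carbon, such as pyridin-3-yl, pyrimidin-2-yl, or a pyridin-2-yl ring carrying an amine or a carboxylic acid. Going by these compounds, the tert-butyl group also stays fixed throughout, so it remains unknown whether the match between pyridin-2-yl and pyrazin-2-yl would persist with a methyl group or a longer chain in its place.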